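The source may hold more compounds than are shown below. What is called first, only, known or untested is meant among the compounds shown, and "the series" means these compounds.

Going by the values given here, compound 2 `NC(=O)c1c(NC(=O)c2ccccc2C(F)(F)F)sc2c1CCN(C(=S)Nc1ccccc1Cl)C2` is one of three compounds measured in a functional assay on HL-60 cells (Homo sapiens) for antiproliferative activity, with a stated time of 24 h (a higher number here means a weaker inhibitor, a lower number a stronger inhibitor), where compound 2 gives 17600 nM, the second highest of the three numbers. Compound 1 `NC(=O)c1c(NC(=O)c2ccccc2Br)sc2c1CCN(C(=S)Nc1ccccc1Cl)C2` gives 14600 nM in this assay, and the step of a 1.2-fold higher number from compound 1 to compound 2 (0.08 log units; within the scatter) lies within the scatter. Compound 3 `NC(=O)c1c(NC(=O)c2ccc(C(F)(F)F)cc2)sc2c1CCN(C(=S)Nc1ccccc1Cl)C2` gives 36100 nM, reached by a 2.1-fold higher number from compound 2 to compound 3 (0.31 log units; beyond the scatter) and by a 2.5-fold higher number from compound 1 to compound 3 (0.39 log units; beyond the scatter). Compound 4 `Cc1ccccc1NC(=S)N1CCc2c(sc(NC(=O)c3ccccc3C(F)(F)F)c2C(N)=O)C1` differs from compound 2 by methyl in place of chloro on an aromatic carbon. All three measured steps alter the group on the carbonyl carbon and leave the (2-chlorophenyl)amino part untouched, so none of them bears on this change, and no step beyond the scatter is expected. Compound 4 is therefore expected to give about 17600 nM in this assay, between 8000 nM and 40000 nM, which means an expected step of no change at the digits printed from compound 2 to compound 4 (within the scatter).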

Compound 4, half-maximal inhibitory concentration: 25100 nM
Beside the measured number, compound 4's estimate is 1.4-fold (0.15 log units) below it; the range from low to high includes it.
By their numbers in this assay, from the lowest: compounds 1, 2, 4 and 3 (each within the scatter of the next, the first and the last beyond it).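

In this assay, going by these compounds alone, this is the first look at the (2-chlorophenyl)amino part, which the earlier steps left untouched, and methyl in place of chloro gives a 1.4-fold higher number from compound 2 to compound 4 (0.15 log units; within the scatter). On this aromatic carbon the two groups cannot be told apart, so this position accepts either one with the rest of compound 2 held constant. Nothing available speaks to the reason for this result. On these data alone, what an amine or a methoxy group would give on this carbon stays open, as does whether methyl in place of chloro reads the same with the 2-bromophenyl group of compound 1 on the carbonyl carbon.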